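An Acrylamide Added to a Weak Antiproliferative Core

This account rests on a few compounds, and the source may have more. Where it says the series, first, only, none or still open, it means among the compounds named here.

Among the measured compounds shown here, compound 1 `COc1cc(OC)c2c(=O)n(-c3cccc(C(=O)N4CCCCC4)c3)ccc2c1` gives 18600 nM in a functional assay on A549 cells (Homo sapiens) for antiproliferative activity, read by MTT assay, with a stated time of 72 h (a lower number here means a stronger inhibitor, a higher number a weaker inhibitor), one of only two numbers measured so far. Its companion compound 2 `COc1cc(O)c2c(=O)n(-c3cccc(C(=O)N4CCCCC4)c3)ccc2c1` gives 14200 nM, and the step of a 1.3-fold lower number from compound 1 to compound 2 (0.12 log units; within the scatter) lies within the scatter, so the two cannot be ranked. Compound 3 `C=CC(=O)Nc1c(OC)cc(OC)c2c(=O)n(-c3cccc(C(=O)N4CCCCC4)c3)ccc12` carries (vinylcarbonyl)amino in place of hydrogen on an aromatic carbon. For the measured compounds named here, no measured step involves this change, and the single known step speaks only to an oxygen substituent, so it gives no guide to size or direction here. Compound 3 is therefore expected to give 9000 nM, within 2000 nM to 40000 nM. This estimate means an expected step of a 2.1-fold lower number from compound 1 to compound 3 (0.32 log units; beyond the scatter), held with low confidence.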

Compound 3, half-maximal inhibitory concentration: 14700 nM
Estimate against measurement, compound 3: 1.6-fold (0.21 log units) below; low and high end bracket the measured number.
By their numbers in this assay, from the lowest: compounds 2, 3 and 1 (each within the scatter of the next).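

In this assay, placing (vinylcarbonyl)amino on this aromatic carbon of the shared core gives a 1.3-fold lower number from compound 1 to compound 3 (0.10 log units; within the scatter), so the two compounds cannot be told apart. This carbon can therefore carry a group of 5 heavy atoms without the number moving beyond the scatter, which the earlier oxygen step could not show. No available evidence explains this result. The compounds shown leave open what an amine or a longer acyl chain on this same carbon would give. They also leave open whether the double bond of the new group matters.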